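This account rests on a few compounds, and the source may have more. Where it says the series, first, only, none or still open, it means among the compounds named here.

Working notes on the series. Among the compounds with values here, compound 3 `Cc1cccc(C)c1Oc1nc(Nc2ccc(C#N)cc2)nc2ccccc12` gives 35000 nM in an ADME assay on MT4 cells (Homo sapiens) for cytotoxicity, read by MTT assay, with a stated time of 4 days (a lower number here means that less compound is tolerated, a higher number that more compound is tolerated), the lowest of the three numbers so far; compound 1 `CCOc1cc(C#N)cc(OCC)c1Oc1nc(Nc2ccc(C#N)cc2)nc2ccccc12` gives 108000 nM and compound 2 `CCCOc1cc(C#N)cc(OCC)c1Oc1nc(Nc2ccc(C#N)cc2)nc2ccccc12` gives 123000 nM, both beyond the scatter from compound 3. Within the data shown here, the only single-place step measured, a 1.1-fold higher number from compound 1 to compound 2 (0.06 log units; within the scatter), sits on the alkoxy chain and not on the aromatic ring, so it does not bear on the present change. Compound 4 `N#Cc1ccc(Nc2nc(Oc3ccccc3)c3ccccc3n2)cc1` differs from compound 3 by phenyl in place of 2,6-dimethylphenyl on an oxygen on an aromatic ring. Among the measured compounds shown here, no measured step reports the loss of two methyls from this ring, so no direction is established; a step of modest size in either sense, possibly within the scatter, is expected, a 1.3-fold higher number from compound 3 to compound 4 (0.11 log units; within the scatter). Compound 4 is estimated at 45000 nM, range 15000 nM to 140000 nM.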

Compound 4, half-maximal cytotoxic concentration: 370000 nM
Beside the measured number, compound 4's estimate is 8.2-fold (0.91 log units) below it, outside the stated range (above it).
By their numbers in this assay, from the lowest: compound 3; then compounds 1 and 2 (each within the scatter of the next); then compound 4.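

In this assay, the change from 2,6-dimethylphenoxy to phenoxy gives an 11-fold higher number from compound 3 to compound 4 (1.02 log units; beyond the scatter) and is a large step beyond the scatter. The only earlier single-place step, a 1.1-fold higher number from compound 1 to compound 2 (0.06 log units; within the scatter) on the alkoxy chain, stayed within the scatter, so this is the first place in the series shown to shift the number. No measurement on hand speaks to what lies behind this step.

On these data alone, whether a single methyl on the phenyl ring accounts for part of the step remains open, as does how a chloro or methoxy group on that ring would read.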